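The source may hold more compounds than are shown below. What is called first, only, known or untested is meant among the compounds shown, and "the series" means these compounds.

In an ADME assay on HepG2 cells (Homo sapiens) for cytotoxicity, read by MTT assay, with a stated time of 72 h (a higher number here means that more compound is tolerated, a lower number that less compound is tolerated), compound 3 `O=[N+]([O-])c1c(CS(=O)(=O)c2ccccc2)nc2c(-c3ccncc3)cc(Cl)cn12` gives > 50000 nM, which is a limit and not a number. Compound 1 `COc1ccc(-c2cc(Cl)cn3c([N+](=O)[O-])c(CS(=O)(=O)c4ccccc4)nc23)cc1` gives > 3900 nM, also a limit. Compound 2 `O=Cc1ccc(-c2cc(Cl)cn3c([N+](=O)[O-])c(CS(=O)(=O)c4ccccc4)nc23)cc1` gives > 31200 nM, again a limit. Compound 4 `O=[N+]([O-])c1c(CS(=O)(=O)c2ccccc2)nc2c(-c3ccco3)cc(Cl)cn12` carries furan-2-yl in place of pyridin-4-yl on an aromatic carbon. The closest measured changes at this place are a step that the two limits leave unreadable from compound 1 to compound 3 and a step that the two limits leave unreadable from compound 2 to compound 3, so neither offers a size to carry over. With no readable size to lean on, the expected change is an at least 2.0-fold lower number from compound 3 to compound 4 (0.30 log units; that floor lies within the scatter), a modest move towards a lower number. The estimate for compound 4 is an expected 25000 nM, with an expected range from 6000 nM to 60000 nM. The assay may well report only a limit again.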

Compound 4, half-maximal cytotoxic concentration: > 3900 nM
Compound 4: no number, only a limit (the forecaster's own chance of this, stated with the estimate: 75%); the middle value is on the limit's open side.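

In this assay compound 4 gives > 3900 nM, which is a limit and not a number. Among the compounds shown here, all four values are limits, so no step between compound 4 and compound 1, compound 2 or compound 3 can be read. The compounds shown leave open the actual half-maximal cytotoxic concentration of each compound, and whether furan-2-yl and pyridin-4-yl differ at all here.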